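Chloro for ethyl on a sulfonate urea chain

The source may hold more compounds than are shown below. What is called first, only, known or untested is meant among the compounds shown, and "the series" means these compounds.

Compound 1 `CC(C)c1ccccc1OS(=O)(=O)c1ccc(NC(=O)CCCCl)cc1`: 6200 nM
Compound 2 `CCCCCNC(=O)Nc1ccc(S(=O)(=O)Oc2ccccc2C(C)C)cc1`: 4900 nM

In a functional assay on HT-29 cells (Homo sapiens) for antiproliferative activity, read by sulforhodamine B assay, with a stated time of 48 h (on this read-out lower numbers stand for stronger inhibition and higher numbers for weaker inhibition), compound 1 gives 6200 nM and compound 2 gives 4900 nM; the two sit within the scatter of each other, as a 1.3-fold lower number from compound 1 to compound 2 (0.10 log units; within the scatter) shows. Compound 3 `CC(C)c1ccccc1OS(=O)(=O)c1ccc(NC(=O)NCCCCl)cc1` keeps the urea and the shared core of compound 2, with chloro in place of ethyl on a saturated chain carbon, three bonds along the chain from an amide-type nitrogen. Among the compounds with values here, no measured step isolates this change: the only step, from compound 1 to compound 2, swaps related chains but also alters the carbonyl linkage. Within the data shown here, with that small step as the sole guide, the expected change in this assay is none beyond the scatter, a 1.0-fold higher number from compound 2 to compound 3 (0.01 log units; within the scatter). Compound 3 is estimated at 5000 nM, between 2500 nM and 10000 nM.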

Compound 3, half-maximal inhibitory concentration: 6900 nM
Beside the measured number, compound 3's estimate is 1.4-fold (0.14 log units) below it; low and high end bracket the measured number.
By their numbers in this assay, from the lowest: compounds 2, 1 and 3 (each within the scatter of the next).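

In this assay, chloro in place of ethyl on a saturated chain carbon, three bonds along the chain from an amide-type nitrogen, gives a 1.4-fold higher number from compound 2 to compound 3 (0.15 log units; within the scatter), so with the urea held constant this swap does not separate the two compounds. With the urea taking the place of the amide linkage, the read-out gives a 1.1-fold higher number from compound 1 to compound 3 (0.05 log units; within the scatter), so the urea and the amide linkage are not told apart either. On these data alone, whether an amine, a carboxylic acid or a longer chain in place of the chloro would move the number beyond the scatter stays open. No outside evidence bears on these results.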